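Adding a nitro group to a weak bromo compound

The source may report more compounds than this note shows. Statements on the series, on what has been measured and on what is new or still open speak of the compounds shown alone.

Values in a functional assay on KB cells (Homo sapiens) for inhibition; a lower number here means a stronger inhibitor, a higher number a weaker inhibitor:
Compound 1 `Nc1nc2cc(Cl)c(Cl)cc2n1Cc1ccccc1`: 170000 nM
Compound 2 `Clc1cc2nc(Cl)n(Cc3ccccc3)c2cc1Cl`: > 100000 nM, a limit
Compound 3 `Clc1cc2nc(Br)n(Cc3ccccc3)c2cc1Cl`: > 100000 nM, a limit

Compound 3 has no exact number in this assay, only the limit > 100000 nM. Compound 2 and compound 3 both stand at the limit of > 100000 nM in this assay, at which 2 of the 3 values shown sit. Only compound 1 has a true number, 170000 nM.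

Compound 4 `O=[N+]([O-])c1cccc(Cn2c(Br)nc3cc(Cl)c(Cl)cc32)c1` differs from compound 3 in one place: nitro in place of hydrogen on an aromatic carbon. The nitro sits on an aromatic carbon of a six-membered aromatic ring of carbon only, meta to a large group.

Three measured steps could offer a guide: a step that the limit leaves unreadable from compound 1 to compound 2, a step that the limit leaves unreadable from compound 1 to compound 3 and a step that the two limits leave unreadable from compound 2 to compound 3. None of them adds a nitro, and none has a readable size. The data therefore give no reason to expect a step beyond the scatter in this assay, in either direction. The estimated step is a step that the limit leaves unreadable from compound 3 to compound 4. For compound 4 the expected value is 120000 nM, with an estimated range from 40000 nM to 300000 nM.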

Compound 4, half-maximal inhibitory concentration: 150000 nM
Compound 4: the middle estimate sits 1.3-fold (0.10 log units) below what was measured, within the range that was stated.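

No size can be read for the change from compound 3 to compound 4 in this assay, because compound 3 has only a limit there: the limit of > 100000 nM in this assay, at which 2 of the 4 values shown sit. The compounds shown leave open whether adding the nitro strengthens inhibition, weakens it or leaves it unchanged.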